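This account rests on a few compounds, and the source may have more. Where it says the series, first, only, none or still open, it means among the compounds named here.

Measured so far:
Compound 1, `C=CCc1ccc(OCc2cn(-c3ccccc3CO)nn2)c(O)c1`, gives 52.1%.
Compound 2, `C=CCc1ccc(OCc2cn(-c3ccc(C(=O)c4ccccc4)cc3)nn2)c(O)c1`, gives 53.7%.

Both were tested in a functional assay on MIA PaCa-2 cells (Homo sapiens) for inhibition, read by MTT assay, with a stated time of 72 h, tested at 50 uM; on this read-out higher numbers stand for more inhibition of growth at the one concentration tested and lower numbers for less inhibition of growth. Compound 2 and compound 1 give numbers that lie within the usual scatter of each other, so neither can be set apart from the other on this read-out; compound 2 is simply the starting point for the next step.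

Compound 3, `C=CCc1ccc(OCc2cn(-c3ccc(OC)cc3)nn2)c(O)c1`, has not yet been measured. It differs from compound 2 in one place: methoxy in place of benzoyl on an aromatic carbon. Among the measured compounds shown here, no measured pair shows what such a change does here, so the expectation rests on the two values alone.

The step from compound 2 to compound 3 is expected to be small, a number 3.7 percentage points lower from compound 2 to compound 3 (within the scatter), not beyond the scatter in either direction. Compound 3 is therefore estimated to give 50%, most likely between 35% and 65%.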

Compound 3, percent growth inhibition at one concentration: 88.2%
For compound 3 the middle estimate is 38.2 percentage points below the measured one, and the stated range ends below it.
By their numbers in this assay, from the lowest: compounds 1 and 2 (each within the scatter of the next); then compound 3.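

In this assay, methoxy in place of benzoyl on an aromatic carbon, para to a large group, gives a number 34.5 percentage points higher from compound 2 to compound 3 (beyond the scatter), showing that the group at this position can matter greatly, which the two earlier values, lying within the scatter of each other, could not show. Against the other earlier compound, 4-methoxyphenyl in place of 2-(hydroxymethyl)phenyl on an aromatic nitrogen gives a number 36.1 percentage points higher from compound 1 to compound 3 (beyond the scatter), so the methoxy compound stands clear of both. Nothing measured here explains why the change has this effect.

Going by these compounds, it remains open whether the gain comes from the presence of methoxy or from the loss of benzoyl. A plain hydrogen, a fluorine, an ethoxy or an amine at the same position would help separate the two.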